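Amino in place of chloro on a second core

This account rests on a few compounds, and the source may have more. Where it says the series, first, only, none or still open, it means among the compounds named here.

Compound 1 `CSc1nc(Cl)c2ccn(COCCO)c2n1` is the reference point. In a functional assay on HFF cells (Homo sapiens) for cytotoxicity (a higher number here means a weaker inhibitor, a lower number a stronger inhibitor), compound 1 gives 30000 nM. Compound 2 `CSc1nc(N)c2ccn(COCCO)c2n1` carries the change (amino in place of chloro on an aromatic carbon). In this assay compound 2 reaches only a limit of the assay, > 100000 nM. The step of an at least 3.3-fold higher number from compound 1 to compound 2 (0.52 log units; beyond the scatter) is therefore bounded by the limit of > 100000 nM in this assay, at which 1 of the 3 values shown sits. Compound 3 `OCCOCn1ccc2c(Cl)nc(Cl)nc21` differs from compound 1 by chloro in place of methylsulfanyl on an aromatic carbon; in this assay compound 3 gives 100000 nM, which amounts to a 3.3-fold higher number from compound 1 to compound 3 (0.52 log units; beyond the scatter).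

Compound 4 `Nc1nc(Cl)nc2c1ccn2COCCO` has not yet been measured. It differs from compound 3 by amino in place of chloro on an aromatic carbon. This is the same kind of change as that made from compound 1 to compound 2, but not the same: in compound 1 the place is meta to a methylsulfanyl group (2 heavy atoms), whereas in compound 3 it is meta to a chloro group (1 heavy atom). Because the earlier step of this kind gave an at least 3.3-fold higher number from compound 1 to compound 2 (0.52 log units; beyond the scatter), compound 4 is expected to show a 1.5-fold higher number from compound 3 to compound 4 (0.18 log units; within the scatter) in this assay. Compound 4 is thus estimated at 150000 nM in this assay, and the assay may well report only a limit for it.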

Compound 4, half-maximal inhibitory concentration: > 100000 nM
Compound 4: only a limit was reported; the forecaster's own chance of this, stated with the estimate: 70%; the middle value lies beyond the limit too.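

In this assay compound 4 reaches only a limit of the assay, > 100000 nM. On the second core the change of chloro to amino gives a number no lower from compound 3 to compound 4 (the limit leaves the size open), so as far as these two pairs go, the number does not fall on either core: the same change on two cores in this assay, an at least 3.3-fold higher number (0.52 log units; beyond the scatter) from compound 1 to compound 2 and a number no lower (the limit leaves the size open) from compound 3 to compound 4; the limit leaves it open whether they differ. This does not show how large the step is on the second core or whether its size carries over from one core to the other, and the step between the two amino compounds cannot be read either: the limit of > 100000 nM in this assay, at which 2 of the 4 values shown sit.

The compounds shown leave open how a group other than amino, for instance a methoxy group or a dimethylamino group, would behave in place of that chloro on either core. With both amino compounds sitting at the limit, a readable size for this change is still missing on both cores.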